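The compounds below may be only part of what the source reports. "The series", "measured", "known", "first", "only" and "open" are said of these compounds alone.

Measured compounds in a functional assay for agonist activity at G protein-coupled receptor 88 (Homo sapiens), read by HTRF and cAMP accumulation; on this read-out higher numbers stand for an effect only at larger amounts of compound and lower numbers for an effect already at smaller amounts:
compound 1, `CC[C@H](C)[C@H](N)CN(C(=O)[C@@H]1C[C@H]1c1c(F)cccc1F)c1ccc(-c2ccccc2)cc1`, 11000 nM
compound 2, `CC(C)C[C@H](N)CN(C(=O)[C@@H]1C[C@H]1c1ccccc1)c1ccc(-c2cccnc2)cc1`, 10000 nM
compound 3, `CC[C@H](C)[C@H](N)CN(C(=O)[C@@H]1C[C@H]1c1ccccc1)c1ccc(-c2ccc(C(C)(C)C)cc2)cc1`, 750 nM

Compound 3 gives the lowest number of the three in this assay; compound 2 stands nearest, with a number higher by a margin beyond the scatter, and compound 1 furthest, also beyond the scatter. Compound 4 `CC[C@H](C)[C@H](N)CN(C(=O)[C@@H]1C[C@H]1c1ccccc1)c1ccc(-c2ccc(COC)cc2)cc1` has not yet been measured. It differs from compound 3 in one place: methoxymethyl in place of tert-butyl on an aromatic carbon. Within the data shown here, no pair of measured compounds shares this change, so its size is not known from the data. Compound 4 is expected to give a higher number, because compound 3 with its 4-(tert-butyl)phenyl gives 750 nM, the lowest of the three. The step from compound 3 to compound 4 is expected to be a 4.0-fold higher number from compound 3 to compound 4 (0.60 log units; beyond the scatter). For compound 4 the estimate is 3000 nM, with a range from 800 nM to 12000 nM.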

Compound 4, half-maximal effective concentration: 35 nM
Estimate against measurement, compound 4: 86-fold (1.93 log units) above; the measured number lies below the stated range.
By their numbers in this assay, from the lowest: compound 4; then compound 3; then compounds 2 and 1 (each within the scatter of the next).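

In this assay, among these compounds, methoxymethyl in place of tert-butyl on this aromatic carbon gives a 21-fold lower number from compound 3 to compound 4 (1.33 log units; beyond the scatter), the first step here that isolates a single change. It shows that the number responds strongly to the group at this place, and that a group with one fewer heavy atom and one hydrogen-bond acceptor gives the lower number. Nothing available here accounts for the size of this step. On these data alone, whether the oxygen or the chain matters stays open: a propyl chain, an ethoxy group or a hydroxymethyl group at this place would bear on that.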